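This account rests on a few compounds, and the source may have more. Where it says the series, first, only, none or still open, it means among the compounds named here.

Compound 1 `COc1cc(COc2ccc(C(=O)NN)cc2)cc(OC)c1OC`: 264 ug/mL
Compound 2 `CCOc1cc(/C=N/NC(=O)c2ccc(OCc3cc(OC)c(OC)c(OC)c3)cc2)ccc1O`: 106 ug/mL
Compound 3 `COc1cc(COc2ccc(C(=O)N/N=C/c3cccc(O)c3)cc2)cc(OC)c1OC`: > 100 ug/mL

In a physicochemical assay, with a stated time of 30 min (a lower number here means a stronger inhibitor, a higher number a weaker inhibitor), compound 1 gives 264 ug/mL, and compound 2 gives 106 ug/mL. In this assay compound 3 gives only a limit, > 100 ug/mL. Compound 3 therefore stands at the edge of what this assay reports, and the two steps that end at it, a step that the limit leaves unreadable from compound 1 to compound 3 and a step that the limit leaves unreadable from compound 2 to compound 3, cannot be read in size; this follows from the limit of > 100 ug/mL in this assay, at which 1 of the 3 values shown sits.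

Compound 4 `COc1cc(COc2ccc(C(=O)N/N=C/c3ccc(O)cc3)cc2)cc(OC)c1OC` differs from compound 3 only in that it has 4-hydroxyphenyl in place of 3-hydroxyphenyl on a carbon with a double bond to nitrogen. Among the measured compounds shown here, no measured step touches this change directly, and the two steps that lead into compound 3 are unreadable, so the measured steps give neither a size nor a direction for the move from compound 3 to compound 4. With compound 3 at the limit, the step that the limit leaves unreadable from compound 3 to compound 4 is expected to be none beyond the scatter, or at most modest in either direction. Compound 4 is thus expected to sit near the same limit in this assay, and its estimate is 150 ug/mL, with a range from 60 ug/mL to 400 ug/mL.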

Compound 4, half-maximal inhibitory concentration: > 100 ug/mL
Compound 4 gave a limit, no number; the forecaster's own chance of this, stated with the estimate: 60%; the middle value lies beyond the limit too.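

In this assay compound 4 gives > 100 ug/mL as a limit, not a number. Among the compounds shown here, no new step from compound 1, compound 2 or compound 3 to compound 4 can be read in size: the limit of > 100 ug/mL in this assay, at which 2 of the 4 values shown sit. The compounds shown leave open whether this assay separates 4-hydroxyphenyl from 3-hydroxyphenyl at all on the shared core.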